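Replacing dimethylamino in compound 3: what compound 4 may show

This account rests on a few compounds, and the source may have more. Where it says the series, first, only, none or still open, it means among the compounds named here.

Measured in a functional assay (aorta) with Rattus norvegicus as the target; on this read-out higher numbers stand for an effect only at larger amounts of compound and lower numbers for an effect already at smaller amounts:
- Compound 1 `COc1ccc(-c2nc(N=C(N)N)sc2-c2ccc(OC)cc2)cc1`: 2 uM
- Compound 2 `COc1ccc(-c2nc(/N=C(\N)NC3CCCCC3)sc2-c2ccc(OC)cc2)cc1`: > 100 uM (a limit of the assay, not a number)
- Compound 3 `COc1ccc(-c2nc(CN(C)C)sc2-c2ccc(OC)cc2)cc1`: 8.4 uM

Of the two true numbers, the higher belongs to compound 3 at 8.4 uM. Its nearest neighbour is compound 1 at 2 uM, and a 4.2-fold higher number from compound 1 to compound 3 (0.62 log units; beyond the scatter). Compound 2 gives only a limit, > 100 uM.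

Compound 4 `COc1ccc(-c2nc(CNC(=O)c3cccnc3)sc2-c2ccc(OC)cc2)cc1` keeps the core of compound 3 but carries ((pyridin-3-yl)carbonyl)amino in place of dimethylamino, on a saturated chain carbon bound to an aromatic carbon: ((pyridin-3-yl)carbonyl)amino in place of dimethylamino on a saturated chain carbon bound to an aromatic carbon.

Among the compounds with values here, no measured step changes this place, so the evidence is indirect. The nearest guide is an at least 50-fold higher number from compound 1 to compound 2 (1.69 log units; beyond the scatter), a large step in which a ring-bearing group came in, and an at least 11-fold lower number from compound 2 to compound 3 (1.07 log units; beyond the scatter) is equally large in the opposite direction. The modest 4.2-fold higher number from compound 1 to compound 3 (0.62 log units; beyond the scatter) shows that the number also moves when the group on the core is exchanged. A move towards a higher number in this assay is therefore expected, probably modest, though a large one cannot be excluded.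

The expected change is a 3.0-fold higher number from compound 3 to compound 4 (0.47 log units; beyond the scatter). For compound 4 the estimated value is 25 uM, with an expected range from 6 uM to 100 uM.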

Compound 4, concentration for half-maximal effect: 8.2 uM
Beside the measured number, compound 4's estimate is 3.0-fold (0.48 log units) above it; low and high end bracket the measured number.
By their numbers in this assay, from the lowest: compound 1; then compounds 4 and 3 (each within the scatter of the next). At a limit, above all of these: compound 2.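

Within the data shown here, on the saturated chain carbon bound to an aromatic carbon, the exchange of dimethylamino for ((pyridin-3-yl)carbonyl)amino leaves this assay without a readable change, a place that no earlier step had touched: a 1.0-fold lower number from compound 3 to compound 4 (0.01 log units; within the scatter). This place therefore accepts a group with an aromatic ring, a carbonyl and an amide hydrogen, and compound 4 shows that a ring-bearing group need not bring the large rise seen with the cyclohexyl group of compound 2: an at least 12-fold lower number from compound 2 to compound 4 (1.08 log units; beyond the scatter). Compound 1 still holds the lowest number of the series, and the new group does not close the gap to it, which matches the gap already seen for compound 3: a 4.1-fold higher number from compound 1 to compound 4 (0.61 log units; beyond the scatter).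

As far as these compounds go, compound 2 gives a limit of the assay and not a number, so the true size of its step to compound 4 stays open: the limit of > 100 uM in this assay, at which 1 of the 4 values shown sits. Also open, from the compounds shown here alone, is which part of the new group matters, since a plain phenyl ring in place of the pyridin-3-yl ring, a carboxylic acid or a longer chain at this place could each tell whether the number stays where it is.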